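The compounds below may be only part of what the source reports. "The series", "measured", "known", "first", "only" and "open" are said of these compounds alone.

Of the compounds shown here, three have been tested in a functional assay on the whole organism for inhibition, with Rattus norvegicus as the target, read by paw edema, with a stated time of 2 h, at a dose of 50 mg/kg; on this read-out lower numbers stand for less inhibition and higher numbers for more inhibition at the one dose given (going by the name of the read-out). Compound 1 `CC(=O)c1c(NNc2ccc(Br)cc2)cc(C)oc1=O` gives 47.2% in this assay. Compound 2 `COc1ccc(NNc2cc(C)oc(=O)c2C(C)=O)cc1` gives 49.4% in this assay. Compound 3 `Cc1cc2nn(-c3ccc(Br)cc3)c(C)c2c(=O)o1` gives 50.6% in this assay, and the three numbers all lie within the scatter of one another, so none of the compounds can be called the stronger.

Compound 1 and compound 2 differ in one place: methoxy in place of bromo on an aromatic carbon. This change produced a number 2.2 percentage points higher from compound 1 to compound 2 (within the scatter). Compound 3 is built on a different core from compound 1; how the two cores differ is not broken down here.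

Compound 4 `COc1ccc(-n2nc3cc(C)oc(=O)c3c2C)cc1` has not yet been measured. It stands to compound 3 as compound 2 stands to compound 1: methoxy in place of bromo on an aromatic carbon. The place of the change is described in the same terms in both pairs, so this is the same change made on the other core.

Because the earlier change gave a number 2.2 percentage points higher from compound 1 to compound 2 (within the scatter), a step of similar size, a number 1.4 percentage points higher from compound 3 to compound 4 (within the scatter), is expected from compound 3 to compound 4. Compound 4 is therefore estimated to give about 52% in this assay, probably between 42% and 62%.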

Compound 4, a percentage reported as inhibition, in the whole organism at one dose (the size of the read-out at that dose, not a potency): 53.9%
Compound 4: middle estimate off by 1.9 percentage points, on the low side; low and high end bracket the measured number.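

In this assay, putting methoxy in place of bromo on the core of compound 3 gave a number 3.3 percentage points higher from compound 3 to compound 4 (within the scatter). Set beside the same change on the core of compound 1, the two steps agree with each other: the same change on two cores in this assay, a number 2.2 percentage points higher (within the scatter) from compound 1 to compound 2 and a number 3.3 percentage points higher (within the scatter) from compound 3 to compound 4, 1.1 percentage points apart, within the scatter of two such steps This shows that the change carried from one core to the other without the result differing, but each step is itself within the scatter, so the two pairs do not show that methoxy raises the number on either core, only that no effect beyond the scatter appears on both.

The compounds shown carry only bromo or methoxy at this place, so it remains open whether another group there, such as an amine or a carboxylic acid, would move the number beyond the scatter on either core. As far as these compounds go, the read-out also comes from a single dose and is not a potency, so how these compounds would compare at other doses remains open too.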